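Pancreatic Cell Growth Inhibition by a Modified Carbamate

The source may report more compounds than this note shows. Statements on the series, on what has been measured and on what is new or still open speak of the compounds shown alone.

Measured so far in a functional assay on PANC-1 cells (Homo sapiens) for inhibition, read by MTT assay, with a stated time of 24 h, tested at 10 uM; on this read-out higher numbers stand for more inhibition at the one concentration tested (going by the name of the read-out) and lower numbers for less inhibition:
Compound 1 `CC(C)=CCOc1cc(=O)n(CCCO)c2c1CC(CC=C(C)C)C(C)(C)C2`, 7.5%
Compound 2 `CC(C)=CCC1Cc2c(OCCCNC(=O)c3ccco3)cc(=O)n(CCCO)c2CC1(C)C`, 4.3%
Compound 3 `COc1ccccc1NC(=O)Oc1cc(=O)n(CCCO)c2c1CC(CC=C(C)C)C(C)(C)C2`, 0%

Compound 3 has the lowest of the three numbers, yet its gaps to the others are small: a number 4.3 percentage points lower from compound 2 to compound 3 (within the scatter) and a number 7.5 percentage points lower from compound 1 to compound 3 (within the scatter), both within the scatter. Compound 4 `CC(C)=CCC1Cc2c(OC(=O)Nc3cccc(C(F)(F)F)c3)cc(=O)n(CCCO)c2CC1(C)C` differs from compound 3 by 3-(trifluoromethyl)phenyl in place of 2-methoxyphenyl on an amide-type nitrogen. Going by the values given here, no measured step alters the aryl group on the amide-type nitrogen; the steps seen so far change the chain on the ring oxygen, and all of them stayed within the scatter: a number 3.2 percentage points lower from compound 1 to compound 2 (within the scatter) alongside the two above. With every change so far leaving this assay essentially unmoved, no step beyond the scatter is expected here either, so compound 4 is estimated to give 4%, in a range from 0% to 15%, an expected step of a number 4 percentage points higher from compound 3 to compound 4 (within the scatter).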

Compound 4, a percentage reported as inhibition, at one concentration (the size of the read-out at that concentration, not a potency): 0%
For compound 4 the middle estimate is 4 percentage points above the measured one, and the stated range covers the measured number.
By their numbers in this assay, from the lowest: compounds 3, 4, 2 and 1 (each within the scatter of the next).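

Going by these compounds alone, this is the first step that changes the aryl group on the amide-type nitrogen: 3-(trifluoromethyl)phenyl in place of 2-methoxyphenyl gives no change at the digits printed from compound 3 to compound 4 (within the scatter) in this assay. Two quite different aryl groups at this position therefore give the same printed number, so the swap shows no sign that this aryl group matters here. Nothing available explains this result. Still open, on these data alone, is whether an aryl group carrying an amine or a carboxylic acid, or a longer alkyl chain in place of the aryl group, would move the number at this position.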